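Amide aryl variation on a shared triazole-thioacetamide core

The compounds below may be only part of what the source reports. "The series", "measured", "known", "first", "only" and "open" are said of these compounds alone.

Measured:
compound 1 `Cc1ccc(C)c(NC(=O)CSc2nnc(-c3ccoc3C)n2Cc2ccco2)c1` — 398 nM
compound 2 `Cc1cccc(NC(=O)CSc2nnc(-c3ccoc3C)n2Cc2ccco2)c1C` — > 15800 nM
compound 3 `Cc1occc1-c1nnc(SCC(=O)Nc2ccc(F)c(Cl)c2)n1Cc1ccco1` — 39.8 nM

In a functional assay on CHO cells for antagonist activity at Orexin receptor type 2 (Homo sapiens), read by FLIPR and calcium flux (a lower number here means a stronger inhibitor, a higher number a weaker inhibitor), compound 3 gives the lowest of the two numbers shown; the nearest is compound 1, reached by a 10-fold lower number from compound 1 to compound 3 (1.00 log units; beyond the scatter). For compound 2 the assay reports only a limit, (the limit of > 15800 nM in this assay, at which 1 of the 3 values shown sits), so an at least 39-fold higher number from compound 1 to compound 2 (1.59 log units; beyond the scatter) and an at least 390-fold lower number from compound 2 to compound 3 (2.59 log units; beyond the scatter) are bounds rather than exact steps. Compound 4 `Cc1ccc(NC(=O)CSc2nnc(-c3ccoc3C)n2Cc2ccco2)cc1` differs from compound 3 by 4-methylphenyl in place of 3-chloro-4-fluorophenyl on an amide-type nitrogen. Within the data shown here, no measured step covers this exact change; the three steps above all lie on the same amide nitrogen and are all beyond the scatter, so a change there is expected to move the number. The step from compound 3 to compound 4 is estimated to raise the number, a 7.5-fold higher number from compound 3 to compound 4 (0.88 log units; beyond the scatter). Compound 4 is therefore expected at about 300 nM, within 60 nM to 2000 nM.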

Compound 4, inhibition constant: 39.8 nM
Compound 4: the middle estimate sits 7.5-fold (0.88 log units) above what was measured; measured number outside the range, below it.
By their numbers in this assay, from the lowest: compounds 3 and 4 (each within the scatter of the next); then compound 1. At a limit, above all of these: compound 2.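

Replacing 3-chloro-4-fluorophenyl with 4-methylphenyl on the amide-type nitrogen gives no change at the digits printed from compound 3 to compound 4 (within the scatter), so neither halogen is required to reach this level in this pair. Against the 2,5-dimethylphenyl group, 4-methylphenyl gives a 10-fold lower number from compound 1 to compound 4 (1.00 log units; beyond the scatter), so a halogen-free aryl group can also sit at the low end of the series. Compound 2 has only a limit, so an at least 390-fold lower number from compound 2 to compound 4 (2.59 log units; beyond the scatter) is a bound: the limit of > 15800 nM in this assay, at which 1 of the 4 values shown sits.

As far as these compounds go, it remains open whether an unsubstituted phenyl, 4-methoxyphenyl or 4-carboxyphenyl group on this nitrogen would hold the same level.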